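The source may hold more compounds than are shown below. What is called first, only, known or untested is meant among the compounds shown, and "the series" means these compounds.

In an ADME assay on HEK-293T cells (Homo sapiens) for inhibition, read by CCK-8 assay, with a stated time of 48 h, tested at 20 uM (a higher number here means more inhibition of growth at the concentration tested, a lower number less inhibition of growth), compound 3 `COc1ccc(Cc2nnc(NC(=O)/C(C#N)=C/c3ccccc3OS(=O)(=O)c3ccccc3[N+](=O)[O-])s2)cc1` gives 18%, within the scatter of compound 2 `COc1ccc(Cc2nnc(NC(=O)/C(C#N)=C/c3ccccc3OS(=O)(=O)c3ccc(C)cc3)s2)cc1` at 21%. Compound 1 `Cc1ccc(S(=O)(=O)Oc2cccc(/C=C(\C#N)C(=O)Nc3nnc(-c4ccccc4)s3)c2)cc1`, which differs from both in several places, gives 52%, beyond the scatter of compound 3. Compound 4 `COc1ccc(Cc2nnc(NC(=O)/C(C#N)=C/c3ccccc3OS(=O)(=O)c3ccc(F)cc3)s2)cc1` departs from compound 3 in one place: 4-fluorophenyl in place of 2-nitrophenyl on a sulfonyl sulfur. Among the measured compounds shown here, the only measured step at this sulfonyl sulfur is a number 3 percentage points lower from compound 2 to compound 3 (within the scatter), where 2-nitrophenyl replaced 4-methylphenyl. On that single precedent, no change beyond the scatter is expected in this assay. The estimated step is a number 2 percentage points higher from compound 3 to compound 4 (within the scatter). For compound 4 the expected value is 20%, with an estimated range of 8% to 35%.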

Compound 4, percent growth inhibition at one concentration: 6%
Compound 4: middle estimate off by 14 percentage points, on the high side, outside the stated range (below it).
By their numbers in this assay, from the lowest: compound 4; then compounds 3 and 2 (each within the scatter of the next); then compound 1.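

Among the compounds shown here, the aryl group on the sulfonyl sulfur can shift the reading in this assay beyond the scatter: 4-fluorophenyl in place of 2-nitrophenyl gives a number 12 percentage points lower from compound 3 to compound 4 (beyond the scatter) and fluoro in place of methyl on an aromatic carbon gives a number 15 percentage points lower from compound 2 to compound 4 (beyond the scatter), whereas the only earlier step here, a number 3 percentage points lower from compound 2 to compound 3 (within the scatter), stayed within it. Nothing available accounts for this shift.

As far as these compounds go, whether an amine or a carboxylic acid on that aromatic carbon would give a similar reading remains open. Also open, from the compounds shown here alone, is whether 4-fluorophenyl would have the same effect on the core of compound 1.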